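Sulfanyl substituent variation on the shared core

A few compounds are considered here, and "the series" means these few. Any claim that something is new, unique, unknown or untested is made for them only; others in the source may bear on it.

Three compounds of the shared core have been run in a functional assay on MGC-803 cells (Homo sapiens) for inhibition, read by MTT assay, with a stated time of 72 h; a lower number here means a stronger inhibitor, a higher number a weaker inhibitor. Compound 1 `Cc1cc(N2CC[C@@H](C)[C@@H](N(C)c3ncnc4[nH]ccc34)C2)n2nc(SCC3CC3)nc2n1` gives 9540 nM in this assay. Compound 2 `C=CCSc1nc2nc(C)cc(N3CC[C@@H](C)[C@@H](N(C)c4ncnc5[nH]ccc45)C3)n2n1` gives 32600 nM in this assay. Compound 3 `Cc1cc(N2CC[C@@H](C)[C@@H](N(C)c3ncnc4[nH]ccc34)C2)n2nc(SCc3ccccc3Br)nc2n1` gives 27000 nM in this assay, the second highest of the three numbers, within the scatter of compound 2 and well apart from compound 1.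

Within the data shown here, the steps so far all sit on the saturated chain carbon bound to a sulfur: a 3.4-fold higher number from compound 1 to compound 2 (0.53 log units; beyond the scatter), a 2.8-fold higher number from compound 1 to compound 3 (0.45 log units; beyond the scatter), and a 1.2-fold lower number from compound 2 to compound 3 (0.08 log units; within the scatter). Leaving cyclopropyl costs a modest step; vinyl and 2-bromophenyl read the same within the scatter.

Compound 4 `Cc1cc(N2CC[C@@H](C)[C@@H](N(C)c3ncnc4[nH]ccc34)C2)n2nc(SCc3ccc([N+](=O)[O-])cc3)nc2n1` carries 4-nitrophenyl in place of 2-bromophenyl on a saturated chain carbon bound to a sulfur. Among the measured compounds shown here, no measured step swaps one substituted phenyl for another at this place, so the 2>3 step, which stays within the scatter, is the closest guide. For compound 4 the step of no change at the digits printed from compound 3 to compound 4 (within the scatter) is expected to stay within the scatter. Compound 4 is therefore estimated at 27000 nM in this assay, with a range from 10000 nM to 70000 nM.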

Compound 4, half-maximal inhibitory concentration: 27000 nM
Estimate against measurement, compound 4: no gap at the digits printed, within the range that was stated.
By their numbers in this assay, from the lowest: compound 1; then compounds 3, 4 and 2 (each within the scatter of the next).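

In this assay the change to 4-nitrophenyl on a saturated chain carbon bound to a sulfur gives no change at the digits printed from compound 3 to compound 4 (within the scatter) and shows that a second substituted phenyl reads the same as the first, while a 1.2-fold lower number from compound 2 to compound 4 (0.08 log units; within the scatter) leaves it level with vinyl too. With a 2.8-fold higher number from compound 1 to compound 4 (0.45 log units; beyond the scatter) added, compound 2, compound 3 and compound 4 form one group within the scatter, and compound 1, the cyclopropyl member, stands apart from all three with the lowest number. Nothing measured here bears on the reason for this grouping.

Open, on these data alone, is whether cyclobutyl or a plain propyl chain at this place joins the higher group or stays near compound 1 at 9540 nM. Also open, as far as these compounds go, is how a benzyl group carrying an amine or a carboxylic acid would read in this assay at this place.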